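From Acetyl to 1-Hydroxyethyl on a Shared Core

The compounds below may be only part of what the source reports. "The series", "measured", "known", "first", "only" and "open" are said of these compounds alone.

Of the compounds shown here, two have been measured in an ADME assay on HEK293 cells for agonist activity at Toll-like receptor 8 (Homo sapiens), read by a luciferase reporter, with a stated time of 6 h; on this read-out lower numbers stand for an effect already at smaller amounts and higher numbers for an effect only at larger amounts of compound. Compound 1 `CCCCNc1nc(N)nc2ccc(C#N)cc12` gives 7.1 uM. Compound 2 `CCCCNc1nc(N)nc2ccc(C(C)=O)cc12`, which carries an acetyl in place of the cyano on an aromatic carbon, gives 1.9 uM in this assay, the lowest of the two numbers; the step of a 3.7-fold lower number from compound 1 to compound 2 (0.57 log units; beyond the scatter) lies beyond the scatter. Compound 3 `CCCCNc1nc(N)nc2ccc(C(C)O)cc12` has not been measured. It differs from compound 2 as follows: 1-hydroxyethyl in place of acetyl on an aromatic carbon. Among the measured compounds shown here, the one measured step touches the same aromatic carbon and was modest, yet it exchanged cyano for acetyl, whereas here acetyl gives way to 1-hydroxyethyl, so no measured step speaks to this change directly. Compound 3 is therefore expected to move by about a 2.1-fold higher number from compound 2 to compound 3 (0.32 log units; beyond the scatter) in this assay, a somewhat higher number being judged more likely than a lower one. For compound 3 the estimate is 4 uM, within a range of 1.5 uM to 12 uM.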

Compound 3, minimum effective concentration: 5.8 uM
Beside the measured number, compound 3's estimate is 1.5-fold (0.16 log units) below it; low and high end bracket the measured number.
By their numbers in this assay, from the lowest: compound 2; then compounds 3 and 1 (each within the scatter of the next).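

In this assay the aromatic carbon on the shared core responds to a change that leaves the heavy-atom count untouched: 1-hydroxyethyl in place of acetyl, which adds a hydrogen-bond donor and removes the double bond outside the aromatic rings, gives a 3.1-fold higher number from compound 2 to compound 3 (0.48 log units; beyond the scatter) and so takes back much of what acetyl showed over cyano. 1-Hydroxyethyl and cyano cannot be told apart here, since the change between them gives a 1.2-fold lower number from compound 1 to compound 3 (0.09 log units; within the scatter) and leaves compound 2 alone with the lowest number of the three. No measurement at hand explains why acetyl stands apart.

Whether a carbonyl group is what matters at this carbon stays open, as the compounds shown include no amide, carboxylic acid or longer ketone such as propanoyl there. They also leave open whether the step from acetyl to 1-hydroxyethyl would keep its size with a longer chain or an amine elsewhere on the core.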